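Moving a hydroxyl across a shared core

The source may hold more compounds than are shown below. What is called first, only, known or untested is meant among the compounds shown, and "the series" means these compounds.

Compound 1 `Oc1ccccc1-c1cc(-c2cccs2)cc(-c2ccccc2O)n1` carries two 2-hydroxyphenyl groups and a thiophen-2-yl group on a shared core. In a functional assay on DU-145 cells (Homo sapiens) for cytotoxicity, read by CCK-8 assay (a higher number here means a weaker inhibitor, a lower number a stronger inhibitor), compound 1 reaches only the limit of the method, > 50000 nM. Compound 2 `Oc1cccc(-c2cc(-c3cccs3)cc(-c3ccccc3O)n2)c1` differs from it in one place: 3-hydroxyphenyl in place of 2-hydroxyphenyl on an aromatic carbon. In this assay compound 2 gives 9300 nM. The step is an at least 5.3-fold lower number from compound 1 to compound 2 (0.73 log units; beyond the scatter). Compound 3 `Oc1ccccc1-c1cc(-c2ccsc2)cc(-c2ccccc2O)n1` differs from compound 1 in another place: thiophen-3-yl in place of thiophen-2-yl on an aromatic carbon. In this assay compound 3 also stops at the limit of the method, > 50000 nM. The step is therefore a step that the two limits leave unreadable from compound 1 to compound 3, and because both values sit at the limit of > 50000 nM in this assay, at which 2 of the 3 values shown sit, the two structures cannot be ordered against each other.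

Compound 4 `Oc1cccc(-c2cc(-c3ccsc3)cc(-c3ccccc3O)n2)c1` is not yet measured. Compared with compound 3, (3-hydroxyphenyl in place of 2-hydroxyphenyl on an aromatic carbon). Within the data shown here, this is the same kind of change as the one made between compound 1 and compound 2, though not the same: in compound 1 the place is meta to a thiophen-2-yl group, whereas in compound 3 it is meta to a thiophen-3-yl group. The starting point for compound 4 is known only as a limit, so the expected step can be set beside the earlier one only loosely; the expected step is an at least 4.1-fold lower number from compound 3 to compound 4 (0.61 log units; beyond the scatter), which rests on the first pair because that pair showed an at least 5.3-fold lower number from compound 1 to compound 2 (0.73 log units; beyond the scatter). Compound 4 is accordingly estimated at 12000 nM, with a likely range from 4000 nM to 50000 nM.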

Compound 4, half-maximal inhibitory concentration: > 50000 nM
Compound 4 ended at the assay's limit (the forecaster's own chance of this, stated with the estimate: 35%); middle value at least 4.1-fold (0.61 log units) from the limit.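

In this assay compound 4 gives > 50000 nM, which is a limit of the method and not a number. The change of 2-hydroxyphenyl to 3-hydroxyphenyl, which brought a value inside the range of the method on the core of compound 1, therefore gave no such value on the core of compound 3, yet this does not show that the change does nothing there, and the step between those two compounds cannot be read because both ends rest on the same limit: the limit of > 50000 nM in this assay, at which 3 of the 4 values shown sit. The one readable new result is an at least 5.3-fold higher number from compound 2 to compound 4 (0.73 log units; beyond the scatter), so with a 3-hydroxyphenyl group in place, thiophen-3-yl in place of thiophen-2-yl marks a real difference in this pair, which means that the gain seen with the hydroxyl change held for the thiophen-2-yl compounds shown and did not carry over in any measurable way to the thiophen-3-yl compounds.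

The compounds shown leave open whether compound 4 differs at all from compound 3, since any such difference lies beyond what the method reports. They also leave open what an amine or a carboxylic acid would do in place of the hydroxyl on either aromatic ring, and whether a methoxy group would keep the value of compound 2.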